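The source may hold more compounds than are shown below. What is called first, only, known or untested is meant among the compounds shown, and "the series" means these compounds.

The measured compounds in a functional assay on MCF7 cells (Homo sapiens) for inhibition, read by MTT assay, with a stated time of 48 h; on this read-out higher numbers stand for weaker inhibition and lower numbers for stronger inhibition:

Compound 1, `CCOC(=O)C1=C(N/C=N/c2cccnc2Cl)Nc2[nH]nc(C)c2C1c1ccc(N(C)C)cc1`, gives 4180 nM.
Compound 2, `CCOC(=O)C1=C(N/N=C(/C(C)=O)C(=O)OCC)Nc2[nH]nc(C)c2C1c1ccc(N(C)C)cc1`, reaches only the limit > 100000 nM.
Compound 3, `CCOC(=O)C1=C(N)Nc2[nH]nc(C)c2C1c1ccc(N(C)C)cc1`, gives 5060 nM.

Compound 3 thus carries the higher of the two numbers, but compound 1 is close: a 1.2-fold higher number from compound 1 to compound 3 (0.08 log units; within the scatter). The unmeasured compound 4, `CCOC(=O)C(=NNC1=C(C(=O)OCC)C(c2ccc(N(C)C)cc2)c2c(C)n[nH]c2N1)C(=O)OCC`, grows out of compound 3 by a group of 12 heavy atoms (7 carbon, 1 nitrogen, 4 oxygen; no ring) in place of a hydrogen atom, on an amine nitrogen.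

Two measured steps speak to this change. Compound 2 likewise carries, on the same amine nitrogen, a group without a ring built of carbon, nitrogen and oxygen, and its number sits at the limit (the limit of > 100000 nM in this assay, at which 1 of the 3 values shown sits). Going the other way, an at least 19-fold lower number from compound 2 to compound 3 (1.29 log units; beyond the scatter), and an at least 23-fold higher number from compound 1 to compound 2 (1.37 log units; beyond the scatter). Both steps are large and point the same way: a group of this kind on that nitrogen, in place of hydrogen or of the chloropyridine-bearing group, moves the number far upward in this assay. Compound 4 differs from compound 2 in the group's make-up, so the outcome is not fixed, yet the two steps give the direction.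

Compound 4 is therefore expected to show a 20-fold higher number from compound 3 to compound 4 (1.30 log units; beyond the scatter). The estimate for compound 4 in this assay is 100000 nM, between 20000 nM and 500000 nM, with a real chance that only a limit is reported.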

Compound 4, half-maximal inhibitory concentration: 89800 nM
Estimate against measurement, compound 4: 1.1-fold (0.05 log units) above, within the range that was stated.
By their numbers in this assay, from the lowest: compounds 1 and 3 (each within the scatter of the next); then compound 4. At a limit, above all of these: compound 2.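

Compound 4 turns what compound 2 could only bound into a number in this assay, showing how far a ring-free group on this amine nitrogen moves the read-out: an 18-fold higher number from compound 3 to compound 4 (1.25 log units; beyond the scatter), and a 21-fold higher number from compound 1 to compound 4 (1.33 log units; beyond the scatter). The value of compound 2 remains a limit rather than a number: the limit of > 100000 nM in this assay, at which 1 of the 4 values shown sits. Against that limit, the only comparison is an at least 1.1-fold lower number from compound 2 to compound 4 (0.04 log units; that floor lies within the scatter), so the two ring-free groups cannot be ordered, and the second one shows only that a large rise is not peculiar to the group in compound 2.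

Compound 2 and compound 4 both carry a hydrazone link together with ester or ketone carbonyl groups, so the compounds shown do not separate the contribution of the link from that of the carbonyl groups. From the compounds shown here alone, it also stays open whether a hydrazone ending in a plain methyl or phenyl group, or a carboxylic acid in place of the ethyl esters on that group, would sit near compound 1 and compound 3 or near compound 4.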